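Methoxy for methyl on the aryl group of a fucosidase probe

The compounds below may be only part of what the source reports. "The series", "measured", "known", "first", "only" and "open" are said of these compounds alone.

Measured so far:
compound 1, `OC[C@@]1(c2ccc(F)cc2)NC[C@@H](O)[C@@H]1O`, 0%
compound 2, `Cc1ccc([C@]2(CO)NC[C@@H](O)[C@@H]2O)cc1`, 0%

Both compounds share one core and differ only in the group on the aromatic carbon. In an assay on isolated protein for inhibition of tissue alpha-L-fucosidase (Bos taurus), tested at 1000 uM (on this read-out lower numbers stand for less inhibition and higher numbers for more inhibition at the one concentration tested (going by the name of the read-out)), compound 1 gives 0%. Compound 2, carrying methyl in place of fluoro on an aromatic carbon, gives 0% in this assay, and the step of no change at the digits printed from compound 1 to compound 2 (within the scatter) shows no change within the scatter. Compound 2 therefore stands level with compound 1, with neither compound showing any inhibition at the concentration tested.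

Compound 3, `COc1ccc([C@]2(CO)NC[C@@H](O)[C@@H]2O)cc1`, has not been measured. It differs from compound 2 as follows: methoxy in place of methyl on an aromatic carbon. Going by the values given here, the only step that bears on this change is no change at the digits printed from compound 1 to compound 2 (within the scatter), which replaced one substituent on the same aromatic carbon with another and left the read-out unchanged. On that basis no step beyond the scatter is expected for compound 3 in this assay, and the expected step of no change at the digits printed from compound 2 to compound 3 (within the scatter) is flat. Compound 3 is thus estimated to give 0%, between -5% and 12%, in this assay.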

Compound 3, a percentage reported as inhibition, at one concentration (the size of the read-out at that concentration, not a potency): 2.7%
For compound 3 the middle estimate is 2.7 percentage points below the measured one, and the stated range covers the measured number.
By their numbers in this assay, from the lowest: compounds 1, 2 and 3 (each within the scatter of the next).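

Across this assay, the change to methoxy extends the flat picture to a group with an oxygen: methoxy in place of methyl gives a number 2.7 percentage points higher from compound 2 to compound 3 (within the scatter), and methoxy in place of fluoro gives a number 2.7 percentage points higher from compound 1 to compound 3 (within the scatter). This aromatic carbon, para to a group of 9 heavy atoms, has now carried fluoro, methyl and methoxy, and adding the hydrogen-bond acceptor of methoxy does not separate compound 3 from compound 1 or compound 2 on this read-out. No independent measurement is available to account for this flat result.

The compounds shown leave open whether any group at this position can move the read-out beyond the scatter, since all three values lie within the scatter of one another at the single concentration tested. Going by these compounds, an amine, a carboxylic acid or a longer chain such as ethoxy on the same aromatic carbon would test that, and the effect of changes elsewhere on the shared core also remains open.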